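From aminophenyl to methoxyphenyl on a shared core

The source may report more compounds than this note shows. Statements on the series, on what has been measured and on what is new or still open speak of the compounds shown alone.

Measured in a functional assay on SGC-7901 cells (Homo sapiens) for antiproliferative activity, read by MTT assay, with a stated time of 72 h; a higher number here means a weaker inhibitor, a lower number a stronger inhibitor:
Compound 1 `COc1ccc(-c2ccc3ncn(-c4cc(OC)c(OC)c(OC)c4)c3c2)cc1F`: 430 nM
Compound 2 `COc1cc(-n2cnc3ccc(-c4cccc(N)c4)cc32)cc(OC)c1OC`: 21 nM

Compound 2 holds the lower of the two numbers, and its gap to compound 1 lies beyond the scatter. Compound 3 `COc1cccc(-c2ccc3ncn(-c4cc(OC)c(OC)c(OC)c4)c3c2)c1` keeps the shared core but has methoxy in place of amino on an aromatic carbon, meta to a large group: methoxy in place of amino on an aromatic carbon. Among the measured compounds shown here, only one measured step bears on this change: a 20-fold lower number from compound 1 to compound 2 (1.31 log units; beyond the scatter), a large step with 3-aminophenyl in place of 3-fluoro-4-methoxyphenyl. Its guidance is partial. For the measured compounds named here, compound 1 also carries a methoxy, but within a different group, and no compound with 3-methoxyphenyl has yet been measured. A higher number is therefore expected in this assay, probably by a smaller step than that one. The expected move is a 4.8-fold higher number from compound 2 to compound 3 (0.68 log units; beyond the scatter). For compound 3 the estimated value is 100 nM, with an expected range of 28 nM to 400 nM.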

Compound 3, half-maximal inhibitory concentration: 3310 nM
The estimate for compound 3 lay 33-fold (1.52 log units) below the measured number, and the stated range ends below it.
By their numbers in this assay, from the lowest: compound 2; then compound 1; then compound 3.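

In this assay, among the compounds shown here, the step from amino to methoxy on this aromatic carbon, meta to a large group, isolates a single change for the first time and gives a 160-fold higher number from compound 2 to compound 3 (2.20 log units; beyond the scatter). The earlier step had changed the whole aryl group, whereas this one shows that the low number of compound 2 depends heavily on the amino group at this place. The 3-methoxyphenyl group also falls short of the 3-fluoro-4-methoxyphenyl group, with a 7.7-fold higher number from compound 1 to compound 3 (0.89 log units; beyond the scatter), so a methoxy at this place does not by itself account for the number of compound 1.

Going by these compounds, whether a hydroxyl or a methylamino group here would keep a number near that of compound 2 stays open. So does whether an amino group elsewhere on this phenyl ring would do the same. No measurement shown here explains why the amino-to-methoxy step is so large.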